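The source may report more compounds than this note shows. Statements on the series, on what has been measured and on what is new or still open speak of the compounds shown alone.

Measured in an ADME assay on HCT-116 cells (Homo sapiens) for cytotoxicity, read by CellTiter-Glo, with a stated time of 72 h; on this read-out lower numbers stand for stronger inhibition and higher numbers for weaker inhibition:

- Compound 1 `CC1CCN(C2CCN(S(=O)(=O)c3ccccc3Br)CC2)CC1`: > 5000 nM (a limit)
- Compound 2 `Cc1cc(C)c(S(=O)(=O)N2CCC(C(=O)N3CCC(C)CC3)CC2)c(C)c1`: > 5000 nM (a limit)
- Compound 3 `C#CCOCCC1CCCCN1C1CCN(S(=O)(=O)c2ccccc2)CC1`: > 5000 nM (a limit)

None of these three compounds has yet given a number, and the record so far is plain: the limit of > 5000 nM in this assay, at which 3 of the 3 values shown sit. In this assay compound 3 stands at > 5000 nM, which is a limit and not a measured potency.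

Compound 4 `C#CCC1CCCCN1C1CCN(S(=O)(=O)c2ccccc2)CC1` has not yet been measured. It differs from compound 3 in one place: ethynyl in place of (propargyloxy)methyl on a saturated chain carbon bound to a saturated ring carbon. Ethynyl stands in place of (propargyloxy)methyl on a saturated chain carbon bound to a saturated ring carbon.

Among the measured compounds shown here, no measured step between related compounds is available to size this change. No shift beyond the scatter is therefore expected in this assay, and no direction is favoured. The expected change is a step that the limit leaves unreadable from compound 3 to compound 4. Compound 4 is estimated at 6000 nM, with an expected range of 3000 nM to 12000 nM. The most likely report for it is again a limit rather than a number.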

Compound 4, half-maximal inhibitory concentration: > 5000 nM
Compound 4: no number, only a limit (the forecaster's own chance of this, stated with the estimate: 85%); the middle value does not contradict the limit.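

Compound 3 and compound 4 each give only a limit in this assay, so no step can be read between them. The compounds shown leave open what potency any of them has in this assay, because all of them share a single limit: the limit of > 5000 nM in this assay, at which 4 of the 4 values shown sit.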